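Aryl substituent series: the hydroxy to carboxy step

This account rests on a few compounds, and the source may have more. Where it says the series, first, only, none or still open, it means among the compounds named here.

Measured compounds:
compound 1 `Cc1ccc(CCCCCCC(=O)N2CCCC2)cc1`; in an assay on HEK293 cells for inhibition of N-acylethanolamine-hydrolyzing acid amidase (Rattus norvegicus), read by LC-MS, with a stated time of 30 min (on this read-out higher numbers stand for weaker inhibition and lower numbers for stronger inhibition), compound 1 gives 9600 nM
compound 2 `O=C(CCCCCCc1ccc(Cl)cc1)N1CCCC1`; in this assay compound 2 gives 34500 nM
compound 3 `O=C(CCCCCCc1ccc(O)cc1)N1CCCC1`; in this assay compound 3 gives 5600 nM

Compound 3 has the lowest number of the three. Its gap to compound 1 is within the scatter (a 1.7-fold lower number from compound 1 to compound 3 (0.23 log units; within the scatter)), so no order between these two can be claimed; its gap to compound 2 is beyond the scatter (a 6.2-fold lower number from compound 2 to compound 3 (0.79 log units; beyond the scatter)). The methyl to chloro swap gave a 3.6-fold higher number from compound 1 to compound 2 (0.56 log units; beyond the scatter).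

Compound 4 `O=C(O)c1ccc(CCCCCCC(=O)N2CCCC2)cc1` is the next point: carboxy in place of hydroxy on an aromatic carbon. Among the measured compounds shown here, no measured step involves carboxy. The two steps that end at compound 3 show that changing the group at this position moved the number by modest amounts at most, and that in both cases hydroxy sat at the lower end. Carboxy enters more atoms than either earlier swap, so the step is taken as uncertain and leaning toward a higher number. Compound 4 is estimated at 15000 nM, with a range from 4000 nM to 60000 nM. For compound 4 the expected step is a 2.7-fold higher number from compound 3 to compound 4 (0.43 log units; beyond the scatter).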

Compound 4, half-maximal inhibitory concentration: > 100000 nM
Compound 4 was reported as a limit; the forecaster's own chance of this, stated with the estimate: 20%; middle value at least 6.6-fold (0.82 log units) away from the limit.
By their numbers in this assay, from the lowest: compounds 3 and 1 (each within the scatter of the next); then compound 2. At a limit, above all of these: compound 4.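

Compound 4 stands in this assay as a limit, not a number: the limit of > 100000 nM in this assay, at which 1 of the 4 values shown sits. Methyl, chloro and hydroxy on this aromatic carbon, para to a large group, all gave numbers that could be read, whereas carboxy gives an at least 17-fold higher number from compound 3 to compound 4 (1.25 log units; beyond the scatter), an at least 10-fold higher number from compound 1 to compound 4 (1.01 log units; beyond the scatter) and an at least 2.8-fold higher number from compound 2 to compound 4 (0.46 log units; beyond the scatter). The position therefore does not accept every group: the earlier swaps gave modest steps at most, while carboxy gives the first large steps, from hydroxy and from methyl, and the step from chloro is printed only as at least modest.

As far as these compounds go, it stays open whether a methyl ester, a primary amide or an amine at this place would give a similar rise or whether it is specific to the carboxylic acid. From the compounds shown here alone, it also stays open whether a shorter or longer chain would change the size of this step.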